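The source may hold more compounds than are shown below. What is called first, only, known or untested is meant among the compounds shown, and "the series" means these compounds.

In a functional assay on Shh Light II cells (Mus musculus) for inhibition, read by a luciferase reporter (on this read-out higher numbers stand for weaker inhibition and lower numbers for stronger inhibition), compound 1 (`N#Cc1ccccc1NC(=O)N1CCC(c2nc(-c3ccc4ccccc4n3)no2)CC1`) gives 190 nM and compound 2 (`COc1ccccc1NC(=O)N1CCC(c2nc(-c3ccc4ccccc4n3)no2)CC1`) gives 410 nM as the higher of the two numbers, so compound 2 is the weaker inhibitor of this pair. Compound 3 (`COc1ccccc1OC(=O)N1CCC(c2nc(-c3ccc4ccccc4n3)no2)CC1`), not yet measured, differs from compound 2 in one place (2-methoxyphenoxy in place of (2-methoxyphenyl)amino on a carbonyl carbon): 2-methoxyphenoxy in place of (2-methoxyphenyl)amino on a carbonyl carbon. For the measured compounds named here, the only measured step (a 2.2-fold higher number from compound 1 to compound 2 (0.33 log units; beyond the scatter)) is modest, but it concerns methoxy in place of cyano on an aromatic carbon. Going by the values given here, it therefore offers only a rough scale, and no measured pair tests the change on the carbonyl carbon, which leaves the direction uncertain. A step of similar modest size towards a higher number is tentatively expected, and the estimated step (a 2.2-fold higher number from compound 2 to compound 3 (0.34 log units; beyond the scatter)) carries a wide margin. The estimate for compound 3 is 900 nM (expected range 250 nM to 3000 nM).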

Compound 3, half-maximal inhibitory concentration: 250 nM
Beside the measured number, compound 3's estimate is 3.6-fold (0.56 log units) above it; measured number inside the range.
By their numbers in this assay, from the lowest: compounds 1, 3 and 2 (each within the scatter of the next, the first and the last beyond it).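

In this assay, putting 2-methoxyphenoxy in place of (2-methoxyphenyl)amino on a carbonyl carbon gives a 1.6-fold lower number from compound 2 to compound 3 (0.21 log units; within the scatter), so at this position the number stays within the scatter when the group with 1 hydrogen-bond donor gives way to one with 0 hydrogen-bond donors. The second swap at this carbon, 2-methoxyphenoxy in place of (2-cyanophenyl)amino, gives a 1.3-fold higher number from compound 1 to compound 3 (0.12 log units; within the scatter), which is again within the scatter, so compound 3 cannot be told apart from either neighbour, although compound 1 and compound 2 differ beyond it. Nothing available here accounts for this result.

Going by these compounds, it remains open whether 2-cyanophenoxy on the same carbonyl carbon would keep the number of compound 3 in this assay. On these data alone, it is equally open how a benzyl group, which has a carbon at the point of attachment, would compare with these groups.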